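Methanesulfonamide in place of the aryl sulfonamide

This account rests on a few compounds, and the source may have more. Where it says the series, first, only, none or still open, it means among the compounds named here.

Measured so far:
compound 1 `O=S(=O)(Nc1ccc(-c2nc3ccccc3o2)cc1)c1ccccc1O` — > 100000 nM
compound 2 `O=S(=O)(Nc1ccc2oc(-c3ccccc3)nc2c1)c1ccccc1C(F)(F)F` — 80000 nM

In an ADME assay on HEK293 cells (Homo sapiens) for cytotoxicity, read by resazurin assay, with a stated time of 48 h (on this read-out higher numbers stand for lower toxicity in this test and lower numbers for higher toxicity in this test), compound 1 gives only a limit, > 100000 nM, not a number. Compound 2 gives 80000 nM in this assay. Compound 1 sits at the limit of > 100000 nM in this assay, at which 1 of the 2 values shown sits. Compound 3 `CS(=O)(=O)Nc1ccc(-c2nc3ccccc3o2)cc1` differs from compound 1 in one place: methyl in place of 2-hydroxyphenyl on a sulfonyl sulfur. Among the measured compounds shown here, no measured pair shows what such a change does in this assay; both values seen sit at the weak end of toxicity, so the expected step from compound 1 to compound 3 is none beyond the scatter, a number no higher from compound 1 to compound 3 (the limit leaves the size open). Compound 3 is therefore estimated at 100000 nM in this assay, within 40000 nM to 250000 nM, with a fair chance that only a limit is reported again.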

Compound 3, half-maximal cytotoxic concentration: > 100000 nM
Compound 3 gave a limit, no number; the forecaster's own chance of this, stated with the estimate: 60%; the middle value lies on the limit itself.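

In this assay compound 3 gives only a limit, > 100000 nM. Compound 1 also gives only a limit, so no step between compound 1 and compound 3 can be read: the limit of > 100000 nM in this assay, at which 2 of the 3 values shown sit.

The compounds shown leave open how far methyl in place of 2-hydroxyphenyl on a sulfonyl sulfur shifts the value in this assay.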